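Lengthening Methoxy to Ethoxy on a Shared Core

The source may report more compounds than this note shows. Statements on the series, on what has been measured and on what is new or still open speak of the compounds shown alone.

Three measured compounds share one core. Compound 1 `CCOc1nc(-c2cc3ccccc3o2)cc(-c2ccccc2)c1C#N` gives 310000 nM in a functional assay on aorta (strain Wistar) for inhibition, with Thoracic aorta (Rattus norvegicus) as the target (on this read-out lower numbers stand for stronger inhibition and higher numbers for weaker inhibition), and compound 2 `CCOc1nc(-c2cc3ccccc3o2)cc(-c2ccc(F)cc2)c1C#N` gives 396000 nM in this assay, the step being a 1.3-fold higher number from compound 1 to compound 2 (0.11 log units; within the scatter). Compound 3 `COc1nc(-c2cc3ccccc3o2)cc(-c2ccc(C)cc2)c1C#N` gives 266000 nM in this assay, a number that lies within the scatter of both compound 1 and compound 2. Compound 4 `CCOc1nc(-c2cc3ccccc3o2)cc(-c2ccc(C)cc2)c1C#N` differs from compound 3 by methyl in place of hydrogen on a saturated chain carbon bound to an oxygen on an aromatic ring. Among the compounds with values here, no measured step covers this change; the single measured step, from compound 1 to compound 2, stays within the scatter, and all three values sit within the scatter of each other, so no shift beyond the scatter is expected, the expected step being a 1.1-fold higher number from compound 3 to compound 4 (0.05 log units; within the scatter). Compound 4 is therefore estimated at 300000 nM, within a range from 150000 nM to 600000 nM.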

Compound 4, half-maximal inhibitory concentration: 290000 nM
For compound 4 the middle estimate is 1.0-fold (0.01 log units) above the measured one, within the range that was stated.
By their numbers in this assay, from the lowest: compounds 3, 4, 1 and 2 (each within the scatter of the next).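

The change from methoxy to ethoxy can now be read directly: in this assay the step is a 1.1-fold higher number from compound 3 to compound 4 (0.04 log units; within the scatter) and adds no shift beyond the scatter at this position on the shared core. On the aromatic carbon, the other two steps also stay within the scatter: methyl in place of fluoro gives a 1.4-fold lower number from compound 2 to compound 4 (0.14 log units; within the scatter) and methyl in place of hydrogen gives a 1.1-fold lower number from compound 1 to compound 4 (0.03 log units; within the scatter) on the same read-out. No other evidence bears on why these numbers stay so close.

As far as these compounds go, whether a longer chain such as propoxy, or an amine at the same place, would move the number beyond the scatter remains open.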